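The source may hold more compounds than are shown below. What is called first, only, known or untested is meant among the compounds shown, and "the series" means these compounds.

Series notes, trimethoxyphenyl sulfonamides and amides.

Compound 1 `COc1cc(N(Cc2ccc(F)cc2)S(=O)(=O)c2ccc(C)cc2)cc(OC)c1OC` carries a 4-fluorobenzyl group on the sulfonamide nitrogen; in a functional assay on MGC-803 cells (Homo sapiens) for inhibition, read by MTT assay, with a stated time of 48 h (a lower number here means a stronger inhibitor, a higher number a weaker inhibitor), compound 1 gives 3750 nM. Compound 2 `COc1cc(N(Cc2ccc(Br)cc2)S(=O)(=O)c2ccc(C)cc2)cc(OC)c1OC` differs from it by bromo in place of fluoro on an aromatic carbon, and in this assay compound 2 gives 1610 nM. The step is a 2.3-fold lower number from compound 1 to compound 2 (0.37 log units; beyond the scatter).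

Compound 3 `COc1cc(N(Cc2nc3ccccc3[nH]2)C(=O)c2ccc(F)cc2)cc(OC)c1OC` belongs to a different core: the sulfonyl is replaced by a carbonyl and the benzyl by a benzimidazolylmethyl group; the difference between the two cores is not broken down here. In this assay compound 3 gives 23600 nM, the highest number of the three measured, beyond the scatter against both compound 1 and compound 2.

Compound 4 `COc1cc(N(Cc2nc3ccccc3[nH]2)C(=O)c2ccc(Br)cc2)cc(OC)c1OC` is the bromo analogue of compound 3, differing by bromo in place of fluoro on an aromatic carbon. This is the same change as from compound 1 to compound 2, at the same kind of place, though one bond further out it reads (4-fluorophenyl)carbonyl to (4-bromophenyl)carbonyl instead of 4-fluorobenzyl to 4-bromobenzyl, and it is made on a core that is much weaker in this assay. For the measured compounds named here, whether the modest gain from compound 1 to compound 2 carries over to the amide core is the open question; only one such pair is measured.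

Compound 4 is expected to show a step of a 2.0-fold lower number from compound 3 to compound 4 (0.29 log units; within the scatter), a gain of the same order as a 2.3-fold lower number from compound 1 to compound 2 (0.37 log units; beyond the scatter), tempered because the core of compound 3 starts from 23600 nM. The estimate for compound 4 in this assay is 12000 nM, with a range from 5000 nM to 30000 nM.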

Compound 4, half-maximal inhibitory concentration: 14600 nM
Compound 4: middle estimate off by 1.2-fold (0.09 log units), on the low side, and the stated range covers the measured number.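

In this assay the bromo for fluoro change on the core of compound 3 gives a 1.6-fold lower number from compound 3 to compound 4 (0.21 log units; within the scatter), so on this core the step cannot be told apart from repeat measurement. Set beside the step on the core of compound 1, the two do not differ: the same change on two cores in this assay, a 2.3-fold lower number (0.37 log units; beyond the scatter) from compound 1 to compound 2 and a 1.6-fold lower number (0.21 log units; within the scatter) from compound 3 to compound 4, 1.4-fold (0.16 log units) apart, within the scatter of two such steps. This is consistent with the change reading alike on both cores, with both steps pointing the same way, but it does not show that the gain carries over, since only one pair per core is shown and the step on the core of compound 3 alone does not clear the scatter.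

The compounds shown leave open how a chloro, a methoxy or a carboxylic acid in the same place would read on either core, and whether the step would hold on a third core. They also leave open which of the two differences between the cores, carbonyl for sulfonyl or benzimidazolylmethyl for benzyl, accounts for the gap between their numbers, as no compound shown carries one of these differences without the other.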